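A Further Methyl on the Chain of Compound 3

This account rests on a few compounds, and the source may have more. Where it says the series, first, only, none or still open, it means among the compounds named here.

In a functional assay on MCF7 cells (Homo sapiens) for antiproliferative activity, read by MTT assay, with a stated time of 72 h (a higher number here means a weaker inhibitor, a lower number a stronger inhibitor), compound 2 (`CC(=O)NNC(=O)c1csc2ncc(-c3ccc(Br)cc3)n12`) gives 1830 nM and compound 3 (`CCC(=O)NNC(=O)c1csc2ncc(-c3ccc(Br)cc3)n12`) gives 15000 nM while compound 1 (`CCCC(=O)NNC(=O)c1csc2ncc(-c3ccc(OC)cc3)n12`) gives 32800 nM on the same read-out. Compound 3 therefore holds the second highest of these three numbers, closer to compound 1 than to compound 2. Compared with compound 3, compound 4 (`CCCC(=O)NNC(=O)c1csc2ncc(-c3ccc(Br)cc3)n12`) carries methyl in place of hydrogen on a saturated chain carbon, two bonds along the chain from a carbonyl carbon. Going by the values given here, the one measured step of this kind is an 8.2-fold higher number from compound 2 to compound 3 (0.91 log units; beyond the scatter) and there the methyl replaced hydrogen on a saturated chain carbon bound to a carbonyl carbon. Compound 1 has the chain of compound 4 but differs from it elsewhere, so it offers only loose support. A single step sets no trend, so a further rise in this assay is expected, smaller than that step and possibly within the scatter. The expected step is a 1.7-fold higher number from compound 3 to compound 4 (0.24 log units; within the scatter) in size. For compound 4 the value is estimated at 26000 nM with an expected range from 10000 nM to 65000 nM overall.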

Compound 4, half-maximal inhibitory concentration: 27500 nM
Estimate against measurement, compound 4: 1.1-fold (0.02 log units) below; the measured number falls inside the stated range.
By their numbers in this assay, from the lowest: compound 2; then compounds 3, 4 and 1 (each within the scatter of the next, the first and the last beyond it).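

In this assay the further methyl, on a saturated chain carbon two bonds along the chain from a carbonyl carbon, gives (a 1.8-fold higher number from compound 3 to compound 4 (0.26 log units; within the scatter)), so it does not repeat the step at the chain carbon bound to the carbonyl carbon (an 8.2-fold higher number from compound 2 to compound 3 (0.91 log units; beyond the scatter)). Across the whole change, ethyl in place of hydrogen gives (a 15-fold higher number from compound 2 to compound 4 (1.18 log units; beyond the scatter)), and only the first of its two steps lies beyond the scatter. With this chain held constant, bromo in place of methoxy on an aromatic carbon gives (a 1.2-fold lower number from compound 1 to compound 4 (0.08 log units; within the scatter)), so the two groups cannot be told apart here.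

From the compounds shown here alone, whether a longer chain, a branched chain or a terminal amine would stay at this level remains open, as does whether methoxy would match bromo on the shorter chains of compound 2 and compound 3. No supporting data are available to explain any of these steps.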